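A few compounds are considered here, and "the series" means these few. Any claim that something is new, unique, unknown or untested is made for them only; others in the source may bear on it.

Measured so far in an ADME assay on HepG2 cells (Homo sapiens) for cytotoxicity, read by MTT assay, with a stated time of 3 days; a lower number here means that less compound is tolerated, a higher number that more compound is tolerated:

- compound 1 `O=c1nc(NO)c(F)cn1[C@@H]1C[C@@H](O)[C@H](CO)O1`: 920000 nM
- compound 2 `O=c1nc(NO)ccn1[C@@H]1CC[C@H](CO)O1`: 2250000 nM
- compound 3 `Cc1cn([C@@H]2C[C@@H](O)[C@H](CO)O2)c(=O)nc1NO`: 490000 nM

Compound 3 has the lowest of the three numbers in this assay. Among the measured compounds shown here, its nearest neighbour is compound 1, and the only single-change step among the measured compounds is a 1.9-fold lower number from compound 1 to compound 3 (0.27 log units; within the scatter), so these two compounds cannot be told apart. For the measured compounds named here, compound 2, the furthest, gives 2250000 nM, a number beyond the scatter from that of compound 3, but it differs in more than one place, so no single step connects the two.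

Compound 4 `O=c1nc(NO)ccn1[C@@H]1C[C@@H](O)[C@H](CO)O1` is compound 3 with the change (hydrogen in place of methyl on an aromatic carbon). Going by the values given here, the one step that bears on this change is a 1.9-fold lower number from compound 1 to compound 3 (0.27 log units; within the scatter), since it alters the same aromatic carbon, and it stayed within the scatter. Compound 2 also carries hydrogen at that carbon, but its sugar differs as well, so its value can only hint that such compounds are tolerated at higher numbers. The expected step is therefore a 2.0-fold higher number from compound 3 to compound 4 (0.31 log units; beyond the scatter), a modest move toward a higher number. Compound 4 is estimated at 1000000 nM in this assay, with a range from 450000 nM to 2300000 nM.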

Compound 4, half-maximal cytotoxic concentration: 545000 nM
The estimate for compound 4 lay 1.8-fold (0.26 log units) above the measured number, and the stated range covers the measured number.
By their numbers in this assay, from the lowest: compounds 3, 4 and 1 (each within the scatter of the next); then compound 2.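

In this assay, three groups can now be compared on the aromatic carbon ortho to a hydroxyamino group, with the rest of the molecule unchanged. Hydrogen in place of methyl gives a 1.1-fold higher number from compound 3 to compound 4 (0.05 log units; within the scatter) and hydrogen in place of fluoro gives a 1.7-fold lower number from compound 1 to compound 4 (0.23 log units; within the scatter) and so, with both steps within the scatter, hydrogen, methyl and fluoro at this carbon cannot be told apart. Among the compounds shown here, the only new step beyond the scatter lies elsewhere, on a saturated ring carbon, where hydroxy in place of hydrogen gives a 4.1-fold lower number from compound 2 to compound 4 (0.62 log units; beyond the scatter) and shows that this position, not the aromatic carbon, is where a single change moved the number, though nothing measured here says why.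

The compounds shown carry only hydrogen, methyl or fluoro on the aromatic carbon, so what a longer chain or an amine would do there remains open. As far as these compounds go, the hydroxy step also rests on a single pair with hydrogen on the aromatic carbon, so whether it holds with methyl or fluoro there is unknown.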